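Removing One Methoxy Group from Compound 1

A few compounds are considered here, and "the series" means these few. Any claim that something is new, unique, unknown or untested is made for them only; others in the source may bear on it.

compound 1 `COc1cc(/C=C2\Cc3c(cc(OC)c(OC)c3OC)C2=O)cc(OC)c1OC`: 2790 nM
compound 2 `COc1cc2c(c(OC)c1OC)C/C(=C\c1cc(OC)c(OC)c(OC)c1OC)C2=O`: > 10000 nM (a limit, not a number)
compound 3 `COc1ccc(/C=C2\Cc3cc(OC)c(OC)c(OC)c3C2=O)cc1O`: > 10000 nM (a limit, not a number)

In a functional assay on A549 cells (Homo sapiens) for antiproliferative activity, read by MTT assay, with a stated time of 48 h (a lower number here means a stronger inhibitor of growth, a higher number a weaker inhibitor of growth), compound 1 gives 2790 nM, the only true number among these three compounds. The other two entries are limits of the assay, so they cannot be ranked against each other.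

The next compound to be tested is compound 4 `COc1cc2c(cc1OC)C(=O)/C(=C/c1cc(OC)c(OC)c(OC)c1)C2`. It has hydrogen in place of methoxy on an aromatic carbon of a six-membered aromatic ring of carbon only, part of a fused or bridged system of two rings: hydrogen in place of methoxy on an aromatic carbon.

Among the compounds with values here, only one measured step bears on this change, and only loosely. It is an at least 3.5-fold higher number from compound 1 to compound 2 (0.55 log units; beyond the scatter), which lies beyond the scatter. That step puts methoxy in place of hydrogen, the reverse kind of swap, and at another place in the molecule, so it cannot simply be run backwards. Also relevant is the limit of > 10000 nM in this assay, at which 2 of the 3 values shown sit. Within the data shown here, compound 1 at 2790 nM therefore gives the only number to start from, and a modest loss of activity is the more likely outcome in this assay. The expected change is a 2.2-fold higher number from compound 1 to compound 4 (0.33 log units; beyond the scatter). For compound 4 the estimated value is 6000 nM, with an expected range from 1800 nM to 18000 nM.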

Compound 4, concentration for 50% growth inhibition: > 10000 nM
Compound 4 was reported as a limit; the forecaster's own chance of this, stated with the estimate: 45%; middle value at least 1.6-fold (0.22 log units) from the limit.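

In this assay, the methoxy group on this aromatic carbon of the fused system, ortho to a fused ring and ortho to a methoxy group, turns out to matter: replacing it with hydrogen gives an at least 3.5-fold higher number from compound 1 to compound 4 (0.55 log units; beyond the scatter) and takes the compound away from the only measured activity in the set. Compound 4 reads > 10000 nM and this is a limit, not a number. Together with an at least 3.5-fold higher number from compound 1 to compound 2 (0.55 log units; beyond the scatter) as the earlier step, this shows activity falling both when a methoxy group is gained at one place and when one is lost at another, and the values shown now crowd at one end of the scale: the limit of > 10000 nM in this assay, at which 3 of the 4 values shown sit.

As far as these compounds go, how much activity is lost beyond that limit stays open, so the true size of this step cannot be told from these compounds. Also open, from the compounds shown here alone, is whether the carbon needs a methoxy group specifically, or whether a hydroxyl group, a fluorine atom or a longer ethoxy chain in the same place would hold the activity of compound 1.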